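Swapping Trifluoromethyl for Dichloro on a Shared Core

The source may hold more compounds than are shown below. What is called first, only, known or untested is meant among the compounds shown, and "the series" means these compounds.

Going by the values given here, compound 3 `O=C(O)CCC(=O)N1N=C(c2c(-c3ccc(C(F)(F)F)cc3)c3ccccc3[nH]c2=O)CC1c1ccc(Cl)cc1` gives 2800 nM in an assay on cells (Oocyte) for negative allosteric modulation of glutamate receptor ionotropic, NMDA 2D (Rattus norvegicus), read by two-electrode voltage clamp (on this read-out higher numbers stand for weaker inhibition and lower numbers for stronger inhibition), the second highest of the three numbers measured so far. Compound 1 `O=C(O)CCC(=O)N1N=C(c2c(-c3ccccc3)c3cc(Cl)ccc3[nH]c2=O)CC1c1ccc(F)cc1` gives 14000 nM in this assay, and compound 2 `O=C(O)CCC(=O)N1N=C(c2c(-c3ccc(Br)cc3)c3ccccc3[nH]c2=O)CC1c1ccc(Cl)cc1` gives 290 nM. Compound 4 `O=C(O)CCC(=O)N1N=C(c2c(-c3ccc(Cl)c(Cl)c3)c3ccccc3[nH]c2=O)CC1c1ccc(Cl)cc1` differs from compound 3 in one place: 3,4-dichlorophenyl in place of 4-(trifluoromethyl)phenyl on an aromatic carbon. Among the compounds with values here, the one measured step that bears on this change is a 9.7-fold higher number from compound 2 to compound 3 (0.98 log units; beyond the scatter), which shows that replacing a halogen with trifluoromethyl raised the number well beyond the scatter. Returning to halogen substitution, now with two chlorines, is therefore expected to move the number back down. Compound 4 is estimated at 500 nM, between 150 nM and 1600 nM, which would mean a 5.6-fold lower number from compound 3 to compound 4 (0.75 log units; beyond the scatter).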

Compound 4, half-maximal inhibitory concentration: 910 nM
Compound 4: the middle estimate sits 1.8-fold (0.26 log units) below what was measured, within the range that was stated.
By their numbers in this assay, from the lowest: compound 2; then compound 4; then compound 3; then compound 1.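

In this assay the change to 3,4-dichlorophenyl gives a 3.1-fold lower number from compound 3 to compound 4 (0.49 log units; beyond the scatter) and so recovers only part of the rise seen with trifluoromethyl at this position. The comparison with the 4-bromophenyl group gives a 3.1-fold higher number from compound 2 to compound 4 (0.50 log units; beyond the scatter) and shows that two chlorines do not match the single bromine here, although both halogen-bearing groups read lower than 4-(trifluoromethyl)phenyl. No measurement accompanies these numbers that could explain this order. The compounds shown leave open how a single chlorine, a methoxy group or an amine on this phenyl ring would read.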